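A few compounds are considered here, and "the series" means these few. Any claim that something is new, unique, unknown or untested is made for them only; others in the source may bear on it.

Series notes, compound 3 to compound 4.

Three compounds of the shared core carry numbers in a functional assay on PC-3 cells (Homo sapiens) for antiproliferative activity, read by MTT assay, with a stated time of 72 h; on this read-out lower numbers stand for stronger inhibition and higher numbers for weaker inhibition. Compound 1 `COc1cc2ncnc(N3CCCc4ccccc43)c2cc1NC(=O)C=C(C)C` gives 6130 nM. Compound 2 `CC/C=C/C(=O)Nc1cc2c(N3CCCc4ccccc43)ncnc2cc1OC` gives 6310 nM; the step of a 1.0-fold higher number from compound 1 to compound 2 (0.01 log units; within the scatter) is within the scatter. Compound 3 `COc1cc2ncnc(N3CCCc4ccccc43)c2cc1NC(=O)/C=C/CN(C)C` gives 1750 nM, the lowest of the three; the steps of a 3.5-fold lower number from compound 1 to compound 3 (0.54 log units; beyond the scatter) and a 3.6-fold lower number from compound 2 to compound 3 (0.56 log units; beyond the scatter) are both modest and beyond the scatter, so compound 3 stands apart from compound 1 and compound 2 in this assay.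

Compound 4 `COc1cc2ncnc(N3CCCc4ccccc43)c2cc1NC(=O)/C=C/CN1CCCC1` is not yet measured. The change from compound 3 is pyrrolidin-1-yl in place of dimethylamino on a saturated chain carbon bound to a double-bonded chain carbon. Among the measured compounds shown here, no measured pair covers this exact swap. The two steps that bear on it, from compound 1 and from compound 2 to compound 3, each put the dimethylamino group in place and each lowered the number modestly; compound 4 keeps a group of the same kind at the same place, with one hydrogen-bond acceptor and no net charge, and differs only in the five-membered non-aromatic ring replacing the two carbons of dimethylamino. On this basis the expected step of a 1.2-fold lower number from compound 3 to compound 4 (0.07 log units; within the scatter) is small, not beyond the scatter, in no firm direction. Compound 4 is therefore estimated at 1500 nM in this assay, with a range from 600 nM to 4000 nM.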

Compound 4, half-maximal inhibitory concentration: 1740 nM
Beside the measured number, compound 4's estimate is 1.2-fold (0.06 log units) below it; the range from low to high includes it.
By their numbers in this assay, from the lowest: compounds 4 and 3 (each within the scatter of the next); then compounds 1 and 2 (each within the scatter of the next).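

In this assay, pyrrolidin-1-yl in place of dimethylamino on a saturated chain carbon bound to a double-bonded chain carbon gives a 1.0-fold lower number from compound 3 to compound 4 (0.00 log units; within the scatter) and so no readable difference: at this place, the five-membered non-aromatic ring and its larger heavy-atom count leave the number where the open dimethylamino group has it. Compound 4 also holds the gap to the two compounds with no amine on the chain, with a 3.6-fold lower number from compound 2 to compound 4 (0.56 log units; beyond the scatter) and with a 3.5-fold lower number from compound 1 to compound 4 (0.55 log units; beyond the scatter) as well, so the modest step is now seen with two different amines and is no longer tied to dimethylamino alone. Nothing at hand gives a reason for these modest steps or for the flat step between the two amines.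

Still open, as far as these compounds go, is whether the number stays flat with a primary amine, or with a longer chain between the double-bonded carbons and the amine. Also open, from the compounds shown here alone, is what a hydroxyl or methoxy group would do in place of the amine on this chain carbon, which would test whether the amine itself is needed for the modest step.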